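A few compounds are considered here, and "the series" means these few. Any claim that something is new, unique, unknown or untested is made for them only; others in the source may bear on it.

Measured compounds:
compound 1, `Fc1ccccc1NC(=S)N/N=C/c1ccc2ccccc2n1`, gives > 100000 nM;
compound 2, `Cc1ccc(NC(=O)N/N=C/c2ccc3ccccc3n2)cc1`, gives > 100000 nM;
compound 3, `CN(C)C(=S)N/N=C/c1nc2ccccc2s1`, gives 830 nM.

These three compounds were tested in a functional assay on SGC-7901 cells (Homo sapiens) for antiproliferative activity, read by sulforhodamine B assay, with a stated time of 72 h; on this read-out higher numbers stand for weaker inhibition and lower numbers for stronger inhibition. For compound 1 the result is only a limit of the assay, > 100000 nM, and not a number. Compound 2 likewise stops at a limit, > 100000 nM. Within the data shown here, compound 3 is the one compound with a full number, 830 nM, so on the values shown compound 1 sits at the weak end, on (the limit of > 100000 nM in this assay, at which 2 of the 3 values shown sit), together with compound 2. No pair of these compounds differs in just one place, so no single step has been measured.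

Compound 4, `S=C(N/N=C/c1ccc2ccccc2n1)Nc1cccc(Cl)c1`, has not yet been tested. It differs from compound 1 by 3-chlorophenyl in place of 2-fluorophenyl on an amide-type nitrogen. The shared core of compound 1 and compound 4 is otherwise unchanged. Among the measured compounds shown here, with no measured step to lean on, the change is expected to give either no movement beyond the scatter or a modest shift towards stronger inhibition, because compound 1 itself sits on the limit of > 100000 nM in this assay, at which 2 of the 3 values shown sit, and has room only in that direction. Compound 4 is therefore estimated at 60000 nM, with a range from 10000 nM to 200000 nM, an expected step of an at least 1.6-fold lower number from compound 1 to compound 4 (0.22 log units; that floor lies within the scatter).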

Compound 4, half-maximal inhibitory concentration: 61300 nM
Beside the measured number, compound 4's estimate is 1.0-fold (0.01 log units) below it, and the stated range covers the measured number.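

Among these compounds, compound 4 is the first compound sharing the core of compound 1 to give a full number in this assay, so this amide-type nitrogen can carry an aryl group that leaves the compound measurable within the range of the assay. Putting 3-chlorophenyl in place of 2-fluorophenyl there gives an at least 1.6-fold lower number from compound 1 to compound 4 (0.21 log units; that floor lies within the scatter), and the two groups match in size by heavy-atom count, so a swap of one halogen-bearing phenyl for another is all that separates the two compounds. That step can be read only as a floor, and its true size stays unknown, because compound 1 gives a limit and not a number: the limit of > 100000 nM in this assay, at which 2 of the 4 values shown sit.

The two groups differ in both the halogen and its ring position, so the compounds shown cannot say which of these matters, or whether the change matters at all beyond the scatter. A 2-chlorophenyl or a 3-fluorophenyl on the same nitrogen would pull the two apart, and a 3-aminophenyl or a 3-carboxyphenyl would show whether this position accepts anything other than a halogen.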